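The compounds below may be only part of what the source reports. "The series", "measured", "known", "first", "only" and "open" are said of these compounds alone.

Of the compounds shown here, three have been measured in a functional assay on cells (Cancer cell lines, Homo sapiens) for cytotoxicity, read by sulforhodamine B assay, with a stated time of 48 h; on this read-out higher numbers stand for weaker inhibition of growth and lower numbers for stronger inhibition of growth. Compound 1 `COc1ccc(C2CC(c3ccccc3)=NN2C2=NC(=O)/C(=C3\C(=O)Nc4ccccc43)S2)cc1` gives 2300 nM. Compound 2 `COc1ccc(C2CC(c3ccc4ccccc4c3)=NN2C2=NC(=O)/C(=C3\C(=O)Nc4ccccc43)S2)cc1` carries naphthalen-2-yl where compound 1 carries phenyl. Compound 2 gives 970 nM, and the step is a 2.4-fold lower number from compound 1 to compound 2 (0.37 log units; beyond the scatter). Compound 3 `COc1ccc(C2CC(c3ccc4ccccc4c3)=NN2C2=NC(=O)/C(=C3\C(=O)Nc4ccc(Br)cc43)S2)cc1` carries bromo in place of hydrogen on an aromatic carbon and gives 110 nM, a step of an 8.8-fold lower number from compound 2 to compound 3 (0.95 log units; beyond the scatter). Compound 2 therefore stands second highest of the three numbers, with compound 1 nearest and compound 3 furthest.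

Compound 4 `O=C1N=C(N2N=C(c3ccc4ccccc4c3)CC2c2ccc(Cl)cc2)S/C1=C1/C(=O)Nc2ccccc21` has not yet been measured. It differs from compound 2 in one place: chloro in place of methoxy on an aromatic carbon. Neither measured step bears directly on this exchange. The step of a 2.4-fold lower number from compound 1 to compound 2 (0.37 log units; beyond the scatter) changed the group on the carbon with a double bond to nitrogen, and the step of an 8.8-fold lower number from compound 2 to compound 3 (0.95 log units; beyond the scatter) put bromo in place of hydrogen on an aromatic carbon; both lowered the number, but neither touched the methoxy. Without a measured precedent for chloro in place of methoxy, no step beyond the scatter in this assay is expected, though a small move in either direction cannot be ruled out. Compound 4 is therefore estimated at 1000 nM, with a range from 400 nM to 2500 nM. The expected step is a 1.0-fold higher number from compound 2 to compound 4 (0.01 log units; within the scatter).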

Compound 4, concentration for 50% growth inhibition: 15400 nM
The estimate for compound 4 lay 15-fold (1.19 log units) below the measured number; measured number outside the range, above it.
By their numbers in this assay, from the lowest: compound 3; then compound 2; then compound 1; then compound 4.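

Going by these compounds alone, exchanging 4-methoxyphenyl for 4-chlorophenyl gives in this assay a step of a 16-fold higher number from compound 2 to compound 4 (1.20 log units; beyond the scatter), the first step that raises the number. Compounds 1, 2 and 3 all keep the methoxy, so they could say nothing about this place; compound 4 shows that the group on this aromatic ring can strongly change the read-out, even though the exchange removes only a methoxy and introduces a single chloro atom. Nothing measured here explains why this exchange has such an effect.

The compounds shown leave open whether the higher number comes from losing the methoxy or from gaining the chloro, a question that hydrogen, fluoro, hydroxy or ethoxy at the same place could help to separate. They also leave open whether the lower number that came with bromo in compound 3 would also appear if the 4-chlorophenyl of compound 4 were present, and whether the naphthalen-2-yl group would matter in the same way there.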